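This account rests on a few compounds, and the source may have more. Where it says the series, first, only, none or still open, it means among the compounds named here.

Measured so far: compound 1 `c1ccc(Nc2c(-c3ccccc3)nc3ccccn23)cc1` with 63.9%; compound 2 `CS(=O)(=O)c1ccc(Nc2c(-c3ccncc3)nc3ccccn23)cc1` with 1.8%; compound 3 `c1ccc(Nc2c(-c3ccncc3)nc3ccccn23)cc1` with 49.9%.

Compound 1 gives the highest of the three values in a functional assay on the whole organism (strain Wistar) for inhibition, with Rattus norvegicus as the target, read by paw edema, with a stated time of 3 h, at a dose of 100 umol/kg by the oral route; a higher number here means more inhibition at the dose given (going by the name of the read-out), a lower number less inhibition; the nearest step to it is a number 14 percentage points lower from compound 1 to compound 3 (beyond the scatter), and compound 2 sits far lower still. The new analogue, compound 4 `CS(=O)(=O)c1ccc(-c2nc3ccccn3c2Nc2ccccc2)cc1`, differs from compound 1 in one place: methylsulfonyl in place of hydrogen on an aromatic carbon. Within the data shown here, one measured step bears on this directly, the same group removed rather than added: a number 48.1 percentage points higher from compound 2 to compound 3 (beyond the scatter). Taking methylsulfonyl away there raised the read-out by a large amount, so adding it to compound 1 is expected to lower it by a comparable amount, a number 48.9 percentage points lower from compound 1 to compound 4 (beyond the scatter). Compound 4 is therefore estimated at 15%, with a range of 0% to 35%.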

Compound 4, a percentage reported as inhibition, in the whole organism at one dose (the size of the read-out at that dose, not a potency): 28.2%
For compound 4 the middle estimate is 13.2 percentage points below the measured one; the range from low to high includes it.
By their numbers in this assay, from the lowest: compound 2; then compound 4; then compound 3; then compound 1.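

On the core of compound 1, methylsulfonyl on an aromatic carbon of a six-membered aromatic ring of carbon only, para to a large group, also costs much of the read-out in this assay. The step is a number 35.7 percentage points lower from compound 1 to compound 4 (beyond the scatter). The loss no longer rests on a single core, and the two steps agree in direction and size: the same change on two cores in this assay, a number 48.1 percentage points higher (beyond the scatter) from compound 2 to compound 3 and a number 35.7 percentage points higher (beyond the scatter) from compound 4 to compound 1, 12.4 percentage points apart, within the scatter of two such steps

The compounds shown leave open whether a smaller group at this place, such as methyl, fluorine or an amine, would lower the read-out as much. They also leave open whether a sulfonamide would behave like methylsulfonyl.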